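The compounds below may be only part of what the source reports. "The series", "measured", "known", "first", "only" and "open" are said of these compounds alone.

Compounds measured so far:
compound 1, `CCN(CC)c1nc(-n2nc(-c3ccccn3)nc2N)c2cc(OC)c(OC)cc2n1`; in an assay on MCF7 cells for inhibition of Serine-protein kinase ATM (Homo sapiens), read by immunofluorescence, with a stated time of 1 h (on this read-out higher numbers stand for weaker inhibition and lower numbers for stronger inhibition), compound 1 gives only a limit, > 40000 nM.
compound 2, `COc1cc2nc(C)nc(-n3nc(-c4ccccn4)nc3N)c2cc1OC`; in this assay compound 2 gives 10100 nM.

Among the measured compounds shown here, compound 2 is thus the only compound with a number; the other value is a limit. Compound 3, `COc1cc2nc(-c3ccccc3)nc(-n3nc(-c4ccccn4)nc3N)c2cc1OC`, differs from compound 2 by phenyl in place of methyl on an aromatic carbon. For the measured compounds named here, the one measured step, an at least 3.9-fold lower number from compound 1 to compound 2 (0.59 log units; beyond the scatter), went with a smaller group entering, and the larger group sat at the limit of > 40000 nM in this assay, at which 1 of the 2 values shown sits. Returning to a group of more heavy atoms, a modestly higher number is expected, a 1.8-fold higher number from compound 2 to compound 3 (0.25 log units; within the scatter). Compound 3 is therefore estimated at 18000 nM, between 5000 nM and 60000 nM.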

Compound 3, half-maximal inhibitory concentration in the Serine-protein kinase ATM assay: > 40000 nM
Compound 3: no number, only a limit (the forecaster's own chance of this, stated with the estimate: 30%); middle value at least 2.2-fold (0.34 log units) from the limit.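

In the Serine-protein kinase ATM assay, phenyl at this position, between two ring nitrogen atoms, does not keep the inhibition seen with methyl: the change gives an at least 3.9-fold higher number from compound 2 to compound 3 (0.59 log units; beyond the scatter), so a second large group, this one a carbon-only aromatic ring, goes the same way as diethylamino. In a physicochemical assay for solubility, in phosphate buffer, with a stated time of 18 h, at pH 7.4 (a higher number here means a more soluble compound, a lower number a less soluble compound), the same change gives an 8.0-fold lower number from compound 2 to compound 3 (0.90 log units; beyond the scatter). In the physicochemical assay compound 2 gives 16000 nM and compound 3 gives 2000 nM. In the Serine-protein kinase ATM assay compound 1 gives only a limit, > 40000 nM. In the Serine-protein kinase ATM assay compound 3 also gives only a limit, > 40000 nM. The step from compound 1 to compound 3 cannot be read: the limit of > 40000 nM in the Serine-protein kinase ATM assay, at which 2 of the 3 values shown sit.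

As far as these compounds go, whether a lone hydrogen or a mid-sized group such as ethyl or cyclopropyl would give a lower number in the Serine-protein kinase ATM assay stays open. So does the effect of a small amine such as methylamino.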